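The source may report more compounds than this note shows. Statements on the series, on what has been measured and on what is new or still open speak of the compounds shown alone.

Measured compounds:
compound 1 `C=C(Br)C(=O)Nc1ccc(/C=C/C(=O)c2ccccc2)cc1` — 3900 nM
compound 2 `C=C(Br)C(=O)Nc1ccc(/C=C/C(=O)c2ccc(OC)cc2)cc1` — 1400 nM
compound 3 `C=C(Br)C(=O)Nc1ccc(C(=O)/C=C/c2cccc(OC)c2)cc1` — 500 nM

In a functional assay on HeLa cells (Homo sapiens) for antiproliferative activity, with a stated time of 48 h (on this read-out lower numbers stand for stronger inhibition and higher numbers for weaker inhibition), the three measured compounds spread over a narrow range. Compound 1 gives 3900 nM; compound 2 gives 1400 nM; compound 3 gives 500 nM, the lowest number of the three. The difference between the core of compound 1 and the core of compound 3 is not broken down here.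

Compound 4 `C=C(Br)C(=O)Nc1ccc(C(=O)/C=C/c2ccc(OC)c(OC)c2)cc1` has not yet been measured. It differs from compound 3 by methoxy in place of hydrogen on an aromatic carbon. The same kind of change is seen from compound 1 to compound 2, (methoxy in place of hydrogen on an aromatic carbon), where it gave a 2.8-fold lower number from compound 1 to compound 2 (0.44 log units; beyond the scatter). The surroundings differ: in compound 4 the entering group sits ortho to a methoxy group and para to a large group, whereas in compound 2 it sits only para to a large group.

For compound 4 in this assay a step of a 1.7-fold lower number from compound 3 to compound 4 (0.22 log units; within the scatter) is expected, because the earlier pair gave a 2.8-fold lower number from compound 1 to compound 2 (0.44 log units; beyond the scatter) and the surroundings are only partly alike. The estimate for compound 4 is 300 nM, expected between 120 nM and 900 nM.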

Compound 4, half-maximal inhibitory concentration: 770 nM
Estimate against measurement, compound 4: 2.6-fold (0.41 log units) below; measured number inside the range.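

In this assay the methoxy-for-hydrogen change does not carry over as a fixed increment from one core to another, and the two steps disagree: the same change on two cores in this assay, a 2.8-fold lower number (0.44 log units; beyond the scatter) from compound 1 to compound 2 and a 1.5-fold higher number (0.19 log units; within the scatter) from compound 3 to compound 4, 4.3-fold (0.63 log units) apart, beyond the scatter of two such steps. The new step, a 1.5-fold higher number from compound 3 to compound 4 (0.19 log units; within the scatter), shows no gain from the added methoxy on the core of compound 3, so the lowering seen on the core of compound 1 cannot be assumed elsewhere in this series. Going by these compounds alone, with only two pairs, this does not show whether the core or the surroundings of the entering group, which in compound 4 sits ortho to a methoxy group, accounts for the gap; the two pairs differ in both.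

Open, from the compounds shown here alone, is how other groups would read at the place taken by the entering methoxy in compound 4, for example a hydroxyl, a fluorine, an amine or a longer chain such as ethoxy. Also open, going by these compounds, is whether the bromine of the shared amide end could give way to chlorine or hydrogen without changing these values.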